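Methoxy for Methyl on a Shared Sulfonamide Core

A few compounds are considered here, and "the series" means these few. Any claim that something is new, unique, unknown or untested is made for them only; others in the source may bear on it.

Measured compounds:
compound 1 `Cc1ccc(S(=O)(=O)Nc2nc(-c3cccc([N+](=O)[O-])c3)cs2)cc1`: 13.3 umol/kg
compound 2 `COc1ccc(S(=O)(=O)Nc2nc(-c3cc(C(F)(F)F)ccc3F)cs2)cc1OC`: 6.6 umol/kg

Of the compounds shown here, two sharing the same core have been tested in an assay on kidney for inhibition of kynurenine 3-monooxygenase (Rattus norvegicus); on this read-out lower numbers stand for an effect already at smaller amounts and higher numbers for an effect only at larger amounts of compound. Compound 1 gives 13.3 umol/kg. Compound 2 gives 6.6 umol/kg. Compound 1 stands at the top of these two numbers, yet the gap to compound 2 lies inside the usual scatter of repeated measurements, so the two cannot be told apart on this evidence, and they differ in several places at once.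

Compound 3 `COc1ccc(S(=O)(=O)Nc2nc(-c3cccc([N+](=O)[O-])c3)cs2)cc1` has not yet been measured. It differs from compound 1 in one place: methoxy in place of methyl on an aromatic carbon. Going by the values given here, no pair of measured compounds differing only in this way exists, so there is no measured step to lean on. With compound 1 at 13.3 umol/kg and compound 2 carrying methoxy groups at 6.6 umol/kg, nothing points to a large shift in either direction. The expected step is a 1.2-fold lower number from compound 1 to compound 3 (0.08 log units; within the scatter), no larger than the scatter. For compound 3 the estimated value is 11 umol/kg, within a range from 4 umol/kg to 30 umol/kg.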

Compound 3, dose for half-maximal effect: 3 umol/kg
Compound 3: middle estimate off by 3.7-fold (0.56 log units), on the high side; the measured number lies below the stated range.
By their numbers in this assay, from the lowest: compound 3; then compounds 2 and 1 (each within the scatter of the next).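

In this assay, going by these compounds alone, changing 4-methylphenyl to 4-methoxyphenyl gives a 4.4-fold lower number from compound 1 to compound 3 (0.65 log units; beyond the scatter), and this is the first comparison here in which only one place differs. It shows that the group on this aromatic carbon, para to a large group, can move the number by more than the usual scatter, which the gap between compound 1 and compound 2 could not show, as those two differ in several places at once. No measurement shown here explains why this swap lowers the number.

The step comes from a single pair, so it remains open whether the same swap would lower the number on a different group at the other end of the molecule, as the compounds shown include no methyl partner for compound 2. From the compounds shown here alone, it also remains open whether the lower number depends on the oxygen itself or on the larger group as a whole, a question that hydroxyl, ethoxy or an amine at this same place would help to settle.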